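The source may hold more compounds than are shown below. What is called first, only, known or untested is meant among the compounds shown, and "the series" means these compounds.

In an ADME assay (liver) for metabolic stability, with Liver microsome (Rattus norvegicus) as the target, using microsomes and NADPH, with a stated time of 30 min, tested at 1 uM (on this read-out higher numbers stand for fast clearance and lower numbers for slow clearance), two compounds with a shared core have been measured. Compound 1 `COc1cc(C(O)(C(F)(F)F)C(F)(F)F)cnc1N1CCN(S(=O)(=O)c2ccc(N)nc2)CC1` gives < 14 mL.min-1.g-1, which is a limit of the assay and not a number. Among the measured compounds shown here, compound 2 `Cn1cc(-c2cc(C(O)(C(F)(F)F)C(F)(F)F)cnc2N2CCN(S(=O)(=O)c3ccc(N)nc3)CC2)cn1` gives 44 mL.min-1.g-1, the only true number so far, which makes it the single firm reference point.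

Compound 3 `CC(C)(C)n1cc(-c2cc(C(O)(C(F)(F)F)C(F)(F)F)cnc2N2CCN(S(=O)(=O)c3ccc(N)nc3)CC2)cn1` differs from compound 2 in one group: tert-butyl in place of methyl on an aromatic nitrogen. In words, tert-butyl takes the place of methyl on an aromatic nitrogen, so 1-methyl-1H-pyrazol-4-yl becomes 1-(tert-butyl)-1H-pyrazol-4-yl.

For the measured compounds named here, only one measured step bears on this change, and only loosely. It is an at least 3.1-fold higher number from compound 1 to compound 2 (0.49 log units; beyond the scatter), beyond the scatter, where 1-methyl-1H-pyrazol-4-yl replaced methoxy on an aromatic carbon. That step introduced the group now being enlarged, and the number in this assay went up. On the strength of an at least 3.1-fold higher number from compound 1 to compound 2 (0.49 log units; beyond the scatter), a further modest rise seems more likely than a fall, though one step is thin support and the result could stay within the scatter. The expected change is a 1.6-fold higher number from compound 2 to compound 3 (0.20 log units; within the scatter). For compound 3 the estimated clearance is 70 mL.min-1.g-1, with an expected range from 30 mL.min-1.g-1 to 160 mL.min-1.g-1.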

Compound 3, intrinsic clearance in microsomes: 459 mL.min-1.g-1
Compound 3: middle estimate off by 6.6-fold (0.82 log units), on the low side, and the stated range ends below it.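

Among the compounds shown here, the size of the group on this aromatic nitrogen turns out to matter far more than the earlier compounds could show: in this assay the swap of methyl for tert-butyl gives a 10-fold higher number from compound 2 to compound 3 (1.02 log units; beyond the scatter), a large step for a change that adds no ring and no hydrogen-bond donor or acceptor. The earlier step showed only that replacing methoxy with 1-methyl-1H-pyrazol-4-yl raised the number, whereas this result shows that the group carried on the pyrazole's nitrogen can have a larger effect than that replacement did. Measured against the methoxy compound, the change to 1-(tert-butyl)-1H-pyrazol-4-yl gives an at least 32-fold higher number from compound 1 to compound 3 (1.51 log units; beyond the scatter), and this size is only a lower bound because compound 1 sits at a limit of the assay and not at a number: the limit of < 14 mL.min-1.g-1 in this assay, at which 1 of the 3 values shown sits.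

The compounds shown leave open whether the number climbs gradually through ethyl and isopropyl on this nitrogen or jumps only with tert-butyl. They also leave open which part of compound 3 is changed during the incubation, and whether a 2-hydroxyethyl group here would bring the number back down.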